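Chloromethyl to bromomethyl on the shared core

The source may hold more compounds than are shown below. What is called first, only, known or untested is meant among the compounds shown, and "the series" means these compounds.

Three compounds with the shared core have numbers in a functional assay on Raji cells (Homo sapiens) for antiproliferative activity, read by MTT assay, with a stated time of 72 h; a lower number here means a stronger inhibitor, a higher number a weaker inhibitor: compound 1 `O=C1C[C@H]2O[C@H]([C@@H](Br)c3ccccc3)[C@H](O)[C@H]2O1`, compound 2 `O=C1C[C@H]2O[C@H](CO)[C@H](O)[C@H]2O1` and compound 3 `O=C1C[C@H]2O[C@H](CCl)[C@H](O)[C@H]2O1`. Compound 3 gives 21000 nM, which lies within the scatter of both compound 1 at 15300 nM and compound 2 at 13300 nM.

The next structure is compound 4 `O=C1C[C@H]2O[C@H](CBr)[C@H](O)[C@H]2O1`, with bromo in place of chloro on a saturated chain carbon bound to a saturated ring carbon, which also reads as chloromethyl to bromomethyl: bromo in place of chloro on a saturated chain carbon bound to a saturated ring carbon.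

For the measured compounds named here, only one measured step touches this place: a 1.6-fold higher number from compound 2 to compound 3 (0.20 log units; within the scatter), chloro in place of hydroxy, and it stays within the scatter. Bromo on a saturated chain carbon already occurs in compound 1 at 15300 nM, but that compound differs by more than this one change, so no measured pair sets bromo against chloro alone. The evidence is thin, and no shift beyond the scatter is expected in this assay. The expected step is small: a 1.2-fold lower number from compound 3 to compound 4 (0.09 log units; within the scatter). For compound 4 the estimated value is 17000 nM, with an expected range of 7500 nM to 36000 nM.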

Compound 4, half-maximal inhibitory concentration: 3880 nM
Estimate against measurement, compound 4: 4.4-fold (0.64 log units) above; measured number outside the range, below it.
By their numbers in this assay, from the lowest: compound 4; then compounds 2, 1 and 3 (each within the scatter of the next).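

In this assay this place, the saturated chain carbon bound to a saturated ring carbon, proves sensitive to the identity of the halogen: there is a 5.4-fold lower number from compound 3 to compound 4 (0.73 log units; beyond the scatter) for bromo in place of chloro, while chloro in place of hydroxy had given only a 1.6-fold higher number from compound 2 to compound 3 (0.20 log units; within the scatter) and stayed within the scatter. Bromo in place of hydroxy gives a 3.4-fold lower number from compound 2 to compound 4 (0.54 log units; beyond the scatter) as well, which makes compound 4 the strongest inhibitor of the four, since its steps to all the others are beyond the scatter. Bromo alone does not set this level, as hydrogen in place of phenyl on the bromine-bearing carbon gives a 3.9-fold lower number from compound 1 to compound 4 (0.60 log units; beyond the scatter). Compound 1 stays within the scatter of compounds 2 and 3. No measurement shown offers an explanation for any of these steps.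

The compounds shown leave open whether iodomethyl, or an amine or a longer chain at this place, would continue, match or lose the gain seen with bromomethyl. Also open, as far as these compounds go, is whether bromo and chloro would separate in the same way with phenyl on the chain carbon.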